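This account rests on a few compounds, and the source may have more. Where it says the series, first, only, none or still open, it means among the compounds named here.

Measured compounds in an ADME assay on cells (Macrophage, Mus musculus) for cytotoxicity, read by MTT assay, with a stated time of 72 h; on this read-out lower numbers stand for higher toxicity in this test and higher numbers for lower toxicity in this test:
compound 1 `COc1ccc(/C=C/C(=O)c2ccccc2)cc1S(=O)(=O)N1CCCC1` gives 57800 nM;
compound 2 `COc1ccc(/C=C/C(=O)c2ccccc2)cc1S(=O)(=O)N1CCOCC1` gives 57800 nM.

Compound 1 stands level with compound 2 at the digits shown, and the only measured step bears this out: no change at the digits printed from compound 1 to compound 2 (within the scatter). Compound 3 `COc1ccc(/C=C/C(=O)c2ccccc2)cc1S(=O)(=O)Nc1ccc(Cl)c(Cl)c1` differs from compound 1 in one place: (3,4-dichlorophenyl)amino in place of pyrrolidin-1-yl on a sulfonyl sulfur. Among the measured compounds shown here, the one step on record concerns the same sulfonyl sulfur, but it swaps one five-membered non-aromatic ring for another and leaves the read-out unchanged; it says nothing direct about an aromatic amine carrying two chlorines and one hydrogen-bond donor. For the measured compounds named here, with no step of that kind measured, compound 3 is expected to stay near compound 1, because no change at the digits printed from compound 1 to compound 2 (within the scatter) showed the read-out tolerant of change at this position. The expected step is a 1.4-fold lower number from compound 1 to compound 3 (0.16 log units; within the scatter). Compound 3 is estimated at 40000 nM, with a range from 15000 nM to 100000 nM.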

Compound 3, half-maximal cytotoxic concentration: 57800 nM
Estimate against measurement, compound 3: 1.4-fold (0.16 log units) below; the range from low to high includes it.
By their numbers in this assay, from the lowest: compounds 1, 2 and 3 (each within the scatter of the next).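

On the sulfonyl sulfur, the change now goes beyond swapping one non-aromatic ring for another: (3,4-dichlorophenyl)amino brings a six-membered aromatic ring of carbon only, two chlorines and one hydrogen-bond donor, and this assay gives no change at the digits printed from compound 1 to compound 3 (within the scatter) and no change at the digits printed from compound 2 to compound 3 (within the scatter) for the same exchange against morpholin-4-yl. Across these three compounds, then, the read-out stays the same at this position despite a larger group with a different ring type and a hydrogen-bond donor. Nothing on record gives a reason for this result.

The compounds shown leave open whether an open-chain group such as diethylamino, or a carboxylic acid on the phenyl ring, would fit the same picture on the sulfonyl sulfur. They also leave open whether replacing the methoxy group on the shared core would change the read-out.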